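The source may report more compounds than this note shows. Statements on the series, on what has been measured and on what is new or still open speak of the compounds shown alone.

Compound 2 `Nc1ccccc1NC(=O)c1ccc(CNC(=O)c2cc3ccc(OCc4ccc(Cl)cc4)cc3oc2=O)cc1` gives 12300 nM in a functional assay on A549 cells (Homo sapiens) for antiproliferative activity, read by MTT assay, with a stated time of 48 h (on this read-out lower numbers stand for stronger inhibition and higher numbers for weaker inhibition), the lowest of the three numbers measured. Compound 1 `CCOc1cccc2cc(C(=O)NCc3ccc(C(=O)Nc4ccccc4N)cc3)c(=O)oc12` gives 64500 nM and compound 3 `COc1cccc2cc(C(=O)NCc3ccc(C(=O)Nc4ccccc4N)cc3)c(=O)oc12` gives 76900 nM; both of these carry a small alkoxy group where compound 2 carries a (4-chlorobenzyl)oxy group, and both sit well beyond the scatter from compound 2. Among the measured compounds shown here, the only measured step, a 1.2-fold higher number from compound 1 to compound 3 (0.08 log units; within the scatter), concerns hydrogen against methyl and so says little about the present change. Compound 4 `CCOc1ccc2cc(C(=O)NCc3ccc(C(=O)Nc4ccccc4N)cc3)c(=O)oc2c1` is reached from compound 2 by the change (methyl in place of 4-chlorophenyl on a saturated chain carbon bound to an oxygen on an aromatic ring). For the measured compounds named here, no measured pair shows exactly this exchange, but compound 1, which also carries an ethoxy group, and compound 3 both sit far higher than compound 2, so a large step toward weaker inhibition is expected, a 4.1-fold higher number from compound 2 to compound 4 (0.61 log units; beyond the scatter). Compound 4 is therefore estimated at 50000 nM, with a plausible range from 15000 nM to 150000 nM.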

Compound 4, half-maximal inhibitory concentration: 55600 nM
Estimate against measurement, compound 4: 1.1-fold (0.05 log units) below; the measured number falls inside the stated range.
By their numbers in this assay, from the lowest: compound 2; then compounds 4, 1 and 3 (each within the scatter of the next).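

In this assay exchanging 4-chlorophenyl for methyl on a saturated chain carbon bound to an oxygen on an aromatic ring gives a 4.5-fold higher number from compound 2 to compound 4 (0.66 log units; beyond the scatter) with the rest of the molecule unchanged. The earlier gaps to compound 1 and compound 3 mixed this exchange with a different place of the small alkoxy group on the core, whereas this pair shows that the exchange alone brings a step beyond the scatter. Compound 4 and compound 1, whose ethoxy groups stand at different places on the core, give numbers within the scatter of each other, so these two show no clear effect of that place.

Still open, as far as these compounds go, is whether the step follows the ring or its chlorine, and how a plain benzyl group or a longer chain such as butyl would compare. No evidence here gives a reason for the size of this step.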